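The compounds below may be only part of what the source reports. "The series", "measured", "known", "first", "only" and "open" are said of these compounds alone.

Measured compounds in the series:

- compound 1, `CCOc1ccc(NC(=O)c2cccc(/C=C3\CC(=O)N(Cc4ccccc4)C3=O)c2)cc1`, 73200 nM
- compound 2, `O=C(NCC1CCCCC1)c1cccc(/C=C2\CC(=O)N(c3ccccc3)C2=O)c1`, > 100000 nM
- compound 3, `Cc1ccc(N2C(=O)C/C(=C\c3cccc(C(=O)Nc4cccc(F)c4)c3)C2=O)cc1`, 96900 nM

In an ADME assay on SW480 cells (Homo sapiens) for cytotoxicity, read by MTT assay, with a stated time of 72 h (on this read-out higher numbers stand for weaker inhibition and lower numbers for stronger inhibition), compound 1 gives 73200 nM. In this assay compound 3 gives 96900 nM. Compound 2 returns only a limit, > 100000 nM, so its position among the three is not fixed by a number; it sits at the limit of > 100000 nM in this assay, at which 1 of the 3 values shown sits. The values of compound 1 and compound 3 lie within the usual scatter of each other, so no order is drawn between them, and the whole set stands at the weak end of the read-out.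

Compound 4, `COc1ccc(NC(=O)c2cccc(/C=C3\CC(=O)N(c4ccccc4)C3=O)c2)cc1`, is not yet measured. It differs from compound 2 in one place: 4-methoxyphenyl in place of cyclohexylmethyl on an amide-type nitrogen. The amide-type nitrogen thus carries an aromatic ring with one hydrogen-bond acceptor where compound 2 carries a saturated ring on a one-carbon link.

Among the measured compounds shown here, no step between two measured compounds is available to size this change. Given that compound 1, which carries an aryl group on the amide-type nitrogen, sits at 73200 nM, and that compound 3, with the same kind of group, sits at 96900 nM, compound 4 is expected to land in the same weak region, with the step of an at least 1.1-fold lower number from compound 2 to compound 4 (0.07 log units; that floor lies within the scatter) expected to fall inside the scatter rather than beyond it. For compound 4 in this assay the expected value is 85000 nM, with a range from 40000 nM to 200000 nM, and a real chance that only a limit is returned.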

Compound 4, half-maximal inhibitory concentration: > 100000 nM
Compound 4 ended at the assay's limit; the forecaster's own chance of this, stated with the estimate: 45%; middle value at least 1.1-fold (0.07 log units) from the limit.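

In this assay compound 4 returns only a limit, > 100000 nM. Compound 2 is also held at a limit, so no step can be read between compound 2 and compound 4: the limit of > 100000 nM in this assay, at which 2 of the 4 values shown sit.

The compounds shown leave open whether 4-methoxyphenyl in place of cyclohexylmethyl on an amide-type nitrogen shifts the value in either direction.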